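Aminothiophene ketone series: aryl swap on the ring nitrogen

The compounds below may be only part of what the source reports. "The series", "measured", "known", "first", "only" and "open" are said of these compounds alone.

Measured compounds:
compound 1, `Nc1scc(CN2CCN(c3ccc(OC(F)(F)F)cc3)CC2)c1C(=O)c1ccc(Cl)cc1`, 0%
compound 2, `Nc1scc(CN2CCN(c3ccncc3)CC2)c1C(=O)c1ccc(Cl)cc1`, -4%

In a functional assay on CHO cells with adenosine receptor A1 (Homo sapiens) as the target, read by cAMP accumulation and immunoassay, with a stated time of 6 min, tested at 0.01 uM (a lower number here means a stronger effect, a higher number a weaker effect of the compound at the concentration tested), compound 1 gives 0%. In this assay compound 2 gives -4%. The two compounds differ only in the aryl group on the amine nitrogen in the ring, and the step of a number 4 percentage points lower from compound 1 to compound 2 (within the scatter) shows that this exchange left the read-out unchanged within the scatter. Compound 2 therefore stands together with compound 1 at a read-out indistinguishable from no effect; the gap between them is within the scatter.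

Compound 3, `Nc1scc(CN2CCN(c3cccc(F)c3)CC2)c1C(=O)c1ccc(Cl)cc1`, is not yet measured in this assay. It differs from compound 2 at the same place: 3-fluorophenyl in place of pyridin-4-yl on an amine nitrogen in a ring.

Among the compounds with values here, the only step that bears on this change is a number 4 percentage points lower from compound 1 to compound 2 (within the scatter), which was within the scatter. Within the data shown here, that step is the sole precedent, and it gives no sign that the aryl group at this position moves the read-out. The step of a number 4 percentage points higher from compound 2 to compound 3 (within the scatter) is therefore expected to be none beyond the scatter. For compound 3 in this assay the estimate is 0%, within a range from -10% to 10%.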

Compound 3, a percentage reported as activity, at one concentration (the size of the read-out at that concentration, not a potency): -18%
Compound 3: the middle estimate sits 18 percentage points above what was measured; the measured number lies below the stated range.
By their numbers in this assay, from the lowest: compound 3; then compounds 2 and 1 (each within the scatter of the next).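

In this assay the aryl group on the amine nitrogen in a ring is no longer without consequence: the read-out shows a number 14 percentage points lower from compound 2 to compound 3 (beyond the scatter) and a number 18 percentage points lower from compound 1 to compound 3 (beyond the scatter), so this position can move the number, which the pair of compound 1 and compound 2 gave no sign of. Exchanging one aryl group for another is therefore not neutral as such: 3-fluorophenyl separates from both pyridin-4-yl and 4-(trifluoromethoxy)phenyl, while those two remain within the scatter of each other. Nothing measured here gives a cause for this modest shift.

Open, on these data alone, is whether the step goes with the fluorine or with the carbon-only ring: a plain phenyl group on the same nitrogen would separate these two readings, and a 4-fluorophenyl group would show whether the place of the fluorine matters. Also open, as far as these compounds go, is whether a 3-chlorophenyl or 3-methoxyphenyl group would follow compound 3 or fall back towards compound 1 and compound 2, and whether any such step would hold at other concentrations.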